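Lengthening the Chain of Compound 2

The source may hold more compounds than are shown below. What is called first, only, known or untested is meant among the compounds shown, and "the series" means these compounds.

In a toxicity assay on HEK-293T cells (Homo sapiens) for cytotoxicity, read by MTT assay, with a stated time of 72 h (on this read-out higher numbers stand for weaker inhibition and lower numbers for stronger inhibition), compound 1 `O=C1c2c[n+]([O-])c3ccccc3c2C(=O)c2c1c1ccccc1n2CCCCn1ccnc1` gives 280 nM and compound 2 `CN1CCN(CCCn2c3c(c4ccccc42)C(=O)c2c[n+]([O-])c4ccccc4c2C3=O)CC1` gives 170 nM. Among the compounds with values here, compound 2 therefore holds the lower of only two numbers, yet the two compounds cannot be told apart. Compound 3 `CN1CCN(CCCCCCn2c3c(c4ccccc42)C(=O)c2c[n+]([O-])c4ccccc4c2C3=O)CC1` departs from compound 2 by a single change: 3-(4-methylpiperazin-1-yl)propyl in place of 4-methylpiperazin-1-yl on a saturated chain carbon, three bonds along the chain from an aromatic nitrogen, on a saturated chain carbon, three bonds along the chain from an aromatic nitrogen. Within the data shown here, one measured step bears on this place, a 1.6-fold lower number from compound 1 to compound 2 (0.22 log units; within the scatter). That step swaps the group carried at the same chain carbon, so it offers only an indirect guide. Among the measured compounds shown here, no measured pair isolates a change of chain alone, and the data give no direction. The expected step, a 1.1-fold lower number from compound 2 to compound 3 (0.05 log units; within the scatter), is therefore none beyond the scatter. For compound 3 the estimated value is 150 nM, with an expected range of 60 nM to 400 nM.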

Compound 3, half-maximal inhibitory concentration: 5800 nM
For compound 3 the middle estimate is 39-fold (1.59 log units) below the measured one; the whole stated range lies below it.
By their numbers in this assay, from the lowest: compounds 2 and 1 (each within the scatter of the next); then compound 3.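

In this assay, the saturated chain carbon three bonds along the chain from an aromatic nitrogen proves sensitive to chain extension: 3-(4-methylpiperazin-1-yl)propyl in place of 4-methylpiperazin-1-yl gives a 34-fold higher number from compound 2 to compound 3 (1.53 log units; beyond the scatter), whereas the earlier change there stayed at a 1.6-fold lower number from compound 1 to compound 2 (0.22 log units; within the scatter). The second new step, a 21-fold higher number from compound 1 to compound 3 (1.32 log units; beyond the scatter), is also large and beyond the scatter, which leaves compound 3 as the weakest inhibitor of the three on this read-out. Nothing measured here accounts for this jump.

As far as these compounds go, it remains open whether the number climbs gradually or abruptly with chain length, a question that a pentyl chain ending in the same 4-methylpiperazin-1-yl would address. Also open, from the compounds shown here alone, is whether the loss is tied to that end group, or would recur with a morpholine or an imidazole on the longer chain.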